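Replacing the heteroaryl sulfanyl arm with 4-methylpiperazin-1-yl

A few compounds are considered here, and "the series" means these few. Any claim that something is new, unique, unknown or untested is made for them only; others in the source may bear on it.

The three measured compounds share one core and differ only in the group held on the chain that carries the amide. In a functional assay on MCF7 cells (Homo sapiens) for cytotoxicity, read by MTT assay, with a stated time of 24 h (a lower number here means a stronger inhibitor, a higher number a weaker inhibitor), compound 1 `Cn1c(-c2ccc(NC(=O)CSc3nc4ccccc4o3)cc2)nc(-c2ccccc2)c1-c1ccccc1` gives 11.2 ug/mL. Compound 2 `Cn1cnnc1SCC(=O)Nc1ccc(-c2nc(-c3ccccc3)c(-c3ccccc3)n2C)cc1` gives 3.2 ug/mL, and compound 3 `Cc1nnc(SCC(=O)Nc2ccc(-c3nc(-c4ccccc4)c(-c4ccccc4)n3C)cc2)s1` gives 3.2 ug/mL. The step of a 3.5-fold lower number from compound 1 to compound 2 (0.54 log units; beyond the scatter) and the step of a 3.5-fold lower number from compound 1 to compound 3 (0.54 log units; beyond the scatter) both lie beyond the scatter, whereas the step of no change at the digits printed from compound 2 to compound 3 (within the scatter) does not. Compound 3 thus stands level with compound 2, and the two together hold the lowest numbers of the three.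

Compound 4 `CN1CCN(CC(=O)Nc2ccc(-c3nc(-c4ccccc4)c(-c4ccccc4)n3C)cc2)CC1` differs from compound 3 by 4-methylpiperazin-1-yl in place of (5-methyl-1,3,4-thiadiazol-2-yl)sulfanyl on a saturated chain carbon bound to a carbonyl carbon. Going by the values given here, none of the measured steps bears directly on this: each of them swaps one heteroaryl for another on the same sulfur, while here the sulfur and the aromatic ring both leave and a saturated ring enters on the chain carbon itself. Among the compounds with values here, the only guide is that the heteroaryl swaps themselves moved the number only modestly, as in a 3.5-fold lower number from compound 1 to compound 3 (0.54 log units; beyond the scatter), and that the smallest heteroaryls gave the lowest numbers. With a change of a different kind, a step of about a 2.5-fold higher number from compound 3 to compound 4 (0.40 log units; beyond the scatter) is expected, with a wide band. Compound 4 is therefore estimated at 8 ug/mL, in the range 2.5 ug/mL to 30 ug/mL.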

Compound 4, half-maximal inhibitory concentration: 76.5 ug/mL
Beside the measured number, compound 4's estimate is 9.6-fold (0.98 log units) below it, and the stated range ends below it.
By their numbers in this assay, from the lowest: compounds 2 and 3 (each within the scatter of the next); then compound 1; then compound 4.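

In this assay the saturated chain carbon bound to a carbonyl carbon shows a far greater sensitivity to this change than the heteroaryl swaps on the sulfur had revealed: 4-methylpiperazin-1-yl gives a 24-fold higher number from compound 3 to compound 4 (1.38 log units; beyond the scatter) and likewise a 24-fold higher number from compound 2 to compound 4 (1.38 log units; beyond the scatter), both large steps. Even the benzoxazolyl compound, which has the highest number among the sulfanyl compounds, does not close the gap, as the same change gives a 6.8-fold higher number from compound 1 to compound 4 (0.83 log units; beyond the scatter), a modest step, so all three heteroaryl sulfanyl arms read lower than the saturated ring in this series. Nothing measured here accounts for the size of these steps.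

This single change removes the sulfur and the aromatic ring and brings in the saturated ring all at once, so the compounds shown do not separate the contribution of each. Still open, on these data alone, are a cyclohexylsulfanyl arm, which would keep the sulfur without an aromatic ring, a morpholin-4-yl on the same chain carbon, and a 4-methylpiperazin-1-yl held on a longer chain.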